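A few compounds are considered here, and "the series" means these few. Any claim that something is new, unique, unknown or untested is made for them only; others in the source may bear on it.

Working notes on the series. Three analogues share one core and differ only in the aryl group on the oxygen of the chain: compound 1 `NC1=NC2(CCOCC2)N(OCCCOc2ccccc2)C(N)=N1`, compound 2 `NC1=NC2(CCOCC2)N(OCCCOc2ccccc2Cl)C(N)=N1` and compound 3 `NC1=NC2(CCOCC2)N(OCCCOc2ccc(F)cc2)C(N)=N1`. In an assay on isolated protein for inhibition of Dihydrofolate reductase (Homo sapiens), read by spectrophotometry, using NADPH, with stated times of 5 s and 6 min (on this read-out higher numbers stand for weaker inhibition and lower numbers for stronger inhibition), compound 1 gives 86.1 nM, and compound 3 gives 46.6 nM. For compound 2 this assay records "not determined" (no result reported), so no number is available for it. The one step that can be read, a 1.8-fold lower number from compound 1 to compound 3 (0.27 log units; within the scatter), leaves the two measured values within the scatter of each other, so on the numbers shown compound 3 sits alongside compound 1 rather than apart from it.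

Compound 4 `NC1=NC2(CCOCC2)N(OCCCOc2ccc(Cl)cc2Cl)C(N)=N1` is still to be measured. Its change relative to compound 3 is 2,4-dichlorophenyl in place of 4-fluorophenyl on an oxygen on a saturated carbon. Among the compounds with values here, no measured step involves a chlorine, since compound 2 has no result; the only guide is the fluoro step from compound 1 to compound 3, which stayed within the scatter. A move beyond the scatter in this assay is therefore not expected, with a slight lowering at most. The estimate for compound 4 in this assay is 40 nM, with a range of 15 nM to 110 nM, which is expected to correspond to a 1.2-fold lower number from compound 3 to compound 4 (0.07 log units; within the scatter).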

Compound 4, half-maximal inhibitory concentration: 7.46 nM
Compound 4: the middle estimate sits 5.4-fold (0.73 log units) above what was measured, and the stated range ends above it.
By their numbers in this assay, from the lowest: compound 4; then compounds 3 and 1 (each within the scatter of the next).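

On an oxygen on a saturated carbon, the aryl group can move the number beyond the scatter: in this assay, 2,4-dichlorophenyl in place of 4-fluorophenyl gives a 6.2-fold lower number from compound 3 to compound 4 (0.80 log units; beyond the scatter), and 2,4-dichlorophenyl in place of phenyl gives a 12-fold lower number from compound 1 to compound 4 (1.06 log units; beyond the scatter), whereas the fluoro step stayed within the scatter. Compound 4 therefore stands apart from the other two measured compounds, and it is the most potent of the three on this read-out. No measurement shown accounts for this result.

Steps to compound 2 cannot be read, so the contribution of each of the two chlorines remains unseparated. Also open, from the compounds shown here alone, is how this result would change with a methoxy group or a carboxylic acid on the phenyl ring, or with a longer chain.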